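Aryl swap on the amide-type nitrogen: outlook for compound 4

The source may report more compounds than this note shows. Statements on the series, on what has been measured and on what is new or still open speak of the compounds shown alone.

In a functional assay on NCI-H1975 cells (Homo sapiens) for inhibition, read by MTT assay, with a stated time of 72 h (a higher number here means a weaker inhibitor, a lower number a stronger inhibitor), compound 1 `O=C(CSc1nc(Nc2ccccc2)c2ccccc2n1)Nc1ccccc1Cl` gives 9610 nM. Compound 2 `O=C(CSc1nc(Nc2ccccc2)c2ccccc2n1)Nc1cccc([N+](=O)[O-])c1` gives 17900 nM, and compound 3 `CCc1ccc(NC(=O)CSc2nc(Nc3ccccc3)c3ccccc3n2)cc1` gives 9910 nM. Compound 3 sits within the scatter of both other compounds, as shown by a 1.0-fold higher number from compound 1 to compound 3 (0.01 log units; within the scatter) and by a 1.8-fold lower number from compound 2 to compound 3 (0.26 log units; within the scatter); three different aryl groups on the amide-type nitrogen leave the number essentially unchanged. Compound 4 `O=C(CSc1nc(Nc2ccccc2)c2ccccc2n1)Nc1ccc(Cl)cc1Cl` carries the change (2,4-dichlorophenyl in place of 4-ethylphenyl on an amide-type nitrogen). Within the data shown here, the steps that bear on it are the earlier swaps of this same aryl group, a 1.0-fold higher number from compound 1 to compound 3 (0.01 log units; within the scatter) and a 1.9-fold higher number from compound 1 to compound 2 (0.27 log units; within the scatter), both within the scatter, and a chlorine-bearing ring is already present in compound 1. No step beyond the scatter is therefore expected in this assay; the expected step is a 1.0-fold lower number from compound 3 to compound 4 (0.02 log units; within the scatter). Compound 4 is expected at 9500 nM, in a range from 4000 nM to 23000 nM.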

Compound 4, half-maximal inhibitory concentration: 8410 nM
Beside the measured number, compound 4's estimate is 1.1-fold (0.05 log units) above it, and the stated range covers the measured number.
By their numbers in this assay, from the lowest: compounds 4, 1, 3 and 2 (each within the scatter of the next, the first and the last beyond it).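

In this assay, among these compounds, the 2,4-dichlorophenyl group on the amide-type nitrogen gives the first step beyond the scatter at this position (a 2.1-fold lower number from compound 2 to compound 4 (0.33 log units; beyond the scatter)), a modest one, seen only against 3-nitrophenyl. Chloro in place of hydrogen on an aromatic carbon (a 1.1-fold lower number from compound 1 to compound 4 (0.06 log units; within the scatter)) and the swap from 4-ethylphenyl (a 1.2-fold lower number from compound 3 to compound 4 (0.07 log units; within the scatter)) both stay within the scatter, so the added chlorine gives no readable change. No evidence on the cause of these steps is available. Open, from the compounds shown here alone, is whether an amine or a carboxylic acid on this aryl ring would move the number further. Also open, going by these compounds, is how a longer chain in place of the aryl group would read.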